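From 2-chlorophenyl to 3-chlorophenyl in a cytotoxic series

The source may hold more compounds than are shown below. What is called first, only, known or untested is meant among the compounds shown, and "the series" means these compounds.

Values so far in a functional assay on HT-1080 cells (Homo sapiens) for cytotoxicity, read by MTT assay, with a stated time of 72 h (on this read-out lower numbers stand for stronger inhibition and higher numbers for weaker inhibition), are these:
- compound 1 (`COc1ccc(/C=C2\CCC/C(=C\c3cccc(OC)c3OC)C2=O)cc1OC`) gives 6400 nM as its value
- compound 2 (`COc1ccc(/C=C2\CCC/C(=C\c3ccccc3Cl)C2=O)cc1OC`) gives 6800 nM as its value

Compound 2 therefore stands level with compound 1, since the two numbers lie within the usual scatter of each other, and neither compound stands apart from the other on this read-out.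

Compound 3 (`COc1ccc(/C=C2\CCC/C(=C\c3cccc(Cl)c3)C2=O)cc1OC`) has not yet been measured. It differs from compound 2 in one place (3-chlorophenyl in place of 2-chlorophenyl on a double-bonded chain carbon bound to a double-bonded ring carbon) and has 3-chlorophenyl in place of 2-chlorophenyl on a double-bonded chain carbon bound to a double-bonded ring carbon. Within the data shown here, no measured step shows what such a change does. Still, compound 1 at 6400 nM and compound 2 at 6800 nM show no gap beyond the scatter while carrying different groups in that place. No step beyond the scatter is thus expected in this assay, and neither direction is clearly favoured. The estimated change is small (a 1.2-fold lower number from compound 2 to compound 3 (0.09 log units; within the scatter)) and stays within the scatter. Compound 3 is estimated at 5500 nM (expected range 2200 nM to 13000 nM).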

Compound 3, half-maximal inhibitory concentration: 4900 nM
Estimate against measurement, compound 3: 1.1-fold (0.05 log units) above; low and high end bracket the measured number.
By their numbers in this assay, from the lowest: compounds 3, 1 and 2 (each within the scatter of the next).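

Placing 3-chlorophenyl in place of 2-chlorophenyl on a double-bonded chain carbon bound to a double-bonded ring carbon gives, in this assay, a 1.4-fold lower number from compound 2 to compound 3 (0.14 log units; within the scatter). Among these compounds, this is the first step at this position that can be read directly, since the two compounds have the same atoms, joined differently, and the two chlorophenyl groups cannot be told apart on this read-out. No measurement shown here bears on the cause of this result, and so the step can be recorded but not explained.

As far as these compounds go, all three compounds carry either chlorophenyl or a dimethoxyphenyl group in this place, and none stands beyond the scatter of the next, so it remains open whether the position can respond at all in this assay. An amine or a carboxylic acid on this phenyl ring, or a longer chain between that ring and the double-bonded chain carbon, could show whether the value can leave this narrow band, and in which direction it would go.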